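The compounds below may be only part of what the source reports. "The series", "measured", "known", "first", "only" and "open" are said of these compounds alone.

In an ADME assay on BE(2)-C cells (Homo sapiens) for cytotoxicity, read by MTT assay, with a stated time of 20 h (on this read-out lower numbers stand for higher toxicity in this test and higher numbers for lower toxicity in this test), compound 3 `Cn1ccc(CNC(=O)C2CCN(C(=O)c3cc4ccccc4n3Cc3ccc(Cl)cc3)CC2)n1` reads > 100000 nM and this is a limit of the assay, not a number. Compound 1 `C[C@@H](NC(=O)C1CCN(C(=O)c2cc3ccccc3n2Cc2ccc(Cl)cc2)CC1)c1ccncc1` gives 92300 nM and compound 2 `CN1CCN(C(=O)C2CCN(C(=O)c3cc4ccccc4n3Cc3ccc(Cl)cc3)CC2)CC1` gives 75600 nM in this assay as numbers. Compound 4 `O=C(NCCCc1ccncc1)C1CCN(C(=O)c2cc3ccccc3n2Cc2ccc(Cl)cc2)CC1` follows from compound 3 by 2-(pyridin-4-yl)ethyl in place of 1-methyl-1H-pyrazol-3-yl on a saturated chain carbon bound to an amide-type nitrogen with 2-(pyridin-4-yl)ethyl in place of 1-methyl-1H-pyrazol-3-yl on a saturated chain carbon bound to an amide-type nitrogen. The measured steps that bear on this change are a 1.2-fold lower number from compound 1 to compound 2 (0.09 log units; within the scatter) and an at least 1.0-fold higher number from compound 1 to compound 3 (0.03 log units; that floor lies within the scatter) and an at least 1.3-fold higher number from compound 2 to compound 3 (0.12 log units; that floor lies within the scatter) and all lie within the scatter. No shift beyond the scatter is therefore expected, and the estimated step is an at least 1.1-fold lower number from compound 3 to compound 4 (0.07 log units; that floor lies within the scatter) in size. Compound 4 is estimated at 85000 nM within an expected range of 45000 nM to 140000 nM in this series.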

Compound 4, half-maximal cytotoxic concentration: 71500 nM
For compound 4 the middle estimate is 1.2-fold (0.08 log units) above the measured one; the range from low to high includes it.
By their numbers in this assay, from the lowest: compounds 4, 2 and 1 (each within the scatter of the next). At a limit, above all of these: compound 3.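

In this assay, the longer 3-(pyridin-4-yl)propyl chain on the amide-type nitrogen gives no shift beyond the scatter against 1-(pyridin-4-yl)ethyl, with a 1.3-fold lower number from compound 1 to compound 4 (0.11 log units; within the scatter), or against 4-methylpiperazin-1-yl on the carbonyl carbon, with a 1.1-fold lower number from compound 2 to compound 4 (0.02 log units; within the scatter). The change from 1-methyl-1H-pyrazol-3-yl to 2-(pyridin-4-yl)ethyl on the saturated chain carbon gives an at least 1.3-fold lower number from compound 3 to compound 4 (0.14 log units; that floor lies within the scatter). Only a floor is known for that step because the reading for compound 3 is a limit of the assay, not a number: the limit of > 100000 nM in this assay, at which 1 of the 4 values shown sits.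

As far as these compounds go, it remains open whether a primary amine or a carboxylic acid in place of pyridin-4-yl at the end of this chain would move the reading beyond the scatter.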